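Swapping chloro for fluoro on the sulfonyl-bearing aryl ring

A few compounds are considered here, and "the series" means these few. Any claim that something is new, unique, unknown or untested is made for them only; others in the source may bear on it.

Compound 1 `COc1ccc2ncc(S(=O)(=O)c3ccc(C)c(Cl)c3)c(N3CCC(C)CC3)c2c1` and compound 2 `Cc1ccc2ncc(S(=O)(=O)c3ccc(C)c(Cl)c3)c(N3CCC(C)CC3)c2c1` share one core and differ only in a group on that core. In an assay on isolated protein for displacement of a labelled ligand from metabotropic glutamate receptor 5 (Homo sapiens), with a stated time of 60 min, tested at 1 uM (a higher number here means more inhibition at the concentration tested (going by the name of the read-out), a lower number less inhibition), compound 1 gives 85%, while compound 2 gives 91%. Of the two numbers recorded, the value of compound 1 is the lower, and its nearest neighbour is compound 2, which sits a number 6 percentage points higher from compound 1 to compound 2 (within the scatter), a gap that says nothing reliable about order.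

From the compounds shown here alone, compound 3 `COc1ccc2ncc(S(=O)(=O)c3ccc(C)c(F)c3)c(N3CCC(C)CC3)c2c1` is untested. It differs from compound 1 by fluoro in place of chloro on an aromatic carbon. For the measured compounds named here, this change sits on the other aromatic ring, not the one touched by the step from compound 1 to compound 2, so no measured step bears directly on it; the one step recorded, a number 6 percentage points higher from compound 1 to compound 2 (within the scatter), only shows that a small change elsewhere in the molecule left the read-out within the scatter.

Without a direct precedent, compound 3 is expected to stay near compound 1, with a step of a number 7 percentage points lower from compound 1 to compound 3 (within the scatter) expected. Compound 3 is therefore estimated at 78% in this assay, in a range from 60% to 92%.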

Compound 3, a percentage reported as inhibition, at one concentration (the size of the read-out at that concentration, not a potency): 73%
For compound 3 the middle estimate is 5 percentage points above the measured one, within the range that was stated.
By their numbers in this assay, from the lowest: compound 3; then compounds 1 and 2 (each within the scatter of the next).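

In this assay, for the compounds shown here, exchanging the 3-chloro-4-methylphenyl group for the 3-fluoro-4-methylphenyl group gives a number 12 percentage points lower from compound 1 to compound 3 (beyond the scatter) and so shows that the read-out responds to the halogen on this carbon, ortho to a methyl group, something the earlier pair could not show because its one change lay elsewhere and stayed within the scatter. The step is modest, and since the read-out comes from a single concentration, it describes a difference in inhibition at that concentration and not a difference in potency. The data shown offer no measurement that would explain why this single-atom exchange lowers the number.

The compounds shown carry only chloro or fluoro at this position, so it remains open how bromo, a nitrile or a trifluoromethyl group would read there, and whether the number follows any order across such a series. Also open, from the compounds shown here alone, is whether the same exchange of chloro for fluoro would lower the number to a similar extent on compound 2, which has methyl where compound 1 has methoxy.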